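A few compounds are considered here, and "the series" means these few. Any claim that something is new, unique, unknown or untested is made for them only; others in the source may bear on it.

Measured so far:
Compound 1, `CC(C)n1ncc2c(C(=O)Nc3cccc(C(N)=O)c3)cc(-c3cccs3)nc21`: 25000 nM
Compound 2, `CC(C)n1ncc2c(C(=O)Nc3ccccc3F)cc(-c3cccnc3)nc21`: 50000 nM

Of the compounds shown here, two have been read in an ADME assay on LLC-MK2 cells (Macaca mulatta) for cytotoxicity, read by spectrophotometry and crystal violet staining, with a stated time of 4 days; on this read-out higher numbers stand for lower toxicity in this test and lower numbers for higher toxicity in this test. Compound 1, with the structure `CC(C)n1ncc2c(C(=O)Nc3cccc(C(N)=O)c3)cc(-c3cccs3)nc21`, gives 25000 nM in this assay. Compound 2, `CC(C)n1ncc2c(C(=O)Nc3ccccc3F)cc(-c3cccnc3)nc21`, gives 50000 nM in the same test. The two numbers lie within the usual scatter of each other, so nothing separates compound 1 from compound 2 on this read-out, and compound 1 has no measured neighbour that differs from it in one place only.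

The next compound is compound 3, `CC(C)n1ncc2c(C(=O)Nc3cccc(S(N)(=O)=O)c3)cc(-c3cccs3)nc21`. It differs from compound 1 in one place: sulfamoyl in place of carbamoyl on an aromatic carbon. Cut one bond further out, the 3-carbamoylphenyl of compound 1 becomes the 3-sulfamoylphenyl of compound 3.

Within the data shown here, no measured pair shows the effect of such a change, and both measured values sit close together high on the scale. On that basis the step of a 1.2-fold higher number from compound 1 to compound 3 (0.08 log units; within the scatter) is expected to stay within the scatter, in no particular direction. Compound 3 is therefore estimated at 30000 nM, with a range from 12000 nM to 75000 nM.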

Compound 3, half-maximal cytotoxic concentration: 25000 nM
Compound 3: middle estimate off by 1.2-fold (0.08 log units), on the high side; measured number inside the range.
By their numbers in this assay, from the lowest: compounds 1, 3 and 2 (each within the scatter of the next).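

In this assay, among these compounds, sulfamoyl in place of carbamoyl on an aromatic carbon of a six-membered aromatic ring of carbon only, meta to a large group, gives no change at the digits printed from compound 1 to compound 3 (within the scatter), the first single change that can be read. The 3-sulfamoylphenyl of compound 3 has more heavy atoms, double bonds outside aromatic rings and hydrogen-bond acceptors than the 3-carbamoylphenyl of compound 1, and this read-out does not separate the two compounds. No other measurement at hand bears on why the two groups read alike.

From the compounds shown here alone, it remains open whether a carboxylic acid, an amine or a longer chain on this same aromatic carbon would also stay within the scatter of compound 1, or would move the number in either direction. Going by these compounds, it is also open whether the swap from carbamoyl to sulfamoyl would read the same way on a compound that carries something other than the shared thiophene-bearing structure of compound 1 and compound 3.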